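A few compounds are considered here, and "the series" means these few. Any claim that something is new, unique, unknown or untested is made for them only; others in the source may bear on it.

Of the compounds shown here, three share one core and have been measured in an assay on mitochondria (strain BALB/c) for inhibition of glycerol-3-phosphate acyltransferase 1, mitochondrial (Mus musculus), read by scintillation counting, with a stated time of 10 min; a higher number here means a weaker inhibitor, a lower number a stronger inhibitor. Compound 1 `CCCCCCCCS(=O)(=O)Nc1cc(-c2ccc(-c3ccccc3)cc2)ccc1C(=O)O` gives 13500 nM. Compound 2 `CCCCCCCCS(=O)(=O)Nc1cc(-c2ccc(OC)cc2)ccc1C(=O)O` gives 13300 nM. Compound 3 `CCCCCCCCS(=O)(=O)Nc1ccc(-c2ccc(CCCC)cc2)cc1C(=O)O` gives 9000 nM. Compound 2 stands among these three numbers with no separation that the measurement can resolve: its value and those of compound 1 and compound 3 all lie within the usual scatter of one another. Among the compounds with values here, the one single-point step among them, a 1.0-fold lower number from compound 1 to compound 2 (0.01 log units; within the scatter), shows that swapping a phenyl for a methoxy at the far end of the molecule left the number essentially where it was.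

The unmeasured compound 4 `CCCCCCCCS(=O)(=O)Nc1cc(CCc2ccccc2)ccc1C(=O)O` differs from compound 2 by phenethyl in place of 4-methoxyphenyl on an aromatic carbon. Within the data shown here, no measured step covers this change directly; the only comparable step, a 1.0-fold lower number from compound 1 to compound 2 (0.01 log units; within the scatter), changed the same distal position and stayed within the scatter. On that basis the step from compound 2 to compound 4 is expected to be small, a 1.1-fold lower number from compound 2 to compound 4 (0.04 log units; within the scatter), in this assay. Compound 4 is therefore estimated at 12000 nM, with a range from 5000 nM to 30000 nM.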

Compound 4, half-maximal inhibitory concentration: 37500 nM
Beside the measured number, compound 4's estimate is 3.1-fold (0.49 log units) below it, outside the stated range (above it).
By their numbers in this assay, from the lowest: compounds 3, 2 and 1 (each within the scatter of the next); then compound 4.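

Within the data shown here, the step of a 2.8-fold higher number from compound 2 to compound 4 (0.45 log units; beyond the scatter) is the first change at this position, para to a carboxy group, that lies beyond the scatter, so the number in this assay does respond to what sits here, even though the swap between compound 1 and compound 2 gave no sign of it. The size of the group cannot account for this on its own: 4-methoxyphenyl and phenethyl have the same count of heavy atoms and each carries one aromatic ring. They differ in the oxygen of the methoxy, a hydrogen-bond acceptor, and in the carbon chain that links phenethyl's ring to the core, and no measurement here explains the step.

The compounds shown leave these two differences tied together. A plain phenyl or a 2-(4-methoxyphenyl)ethyl group at this position would begin to pull them apart.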